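Chloro to fluoro on the aryl ring of compound 1

The compounds below may be only part of what the source reports. "The series", "measured", "known", "first", "only" and "open" are said of these compounds alone.

Compound 1 `CC(C)(C)C(=O)N1N=CCC1c1cccc(Cl)c1` gives the highest of the three numbers in a physicochemical assay for lipophilicity, read by HPLC, measured as chromatographic lipophilicity, at pH 7.4 (on this read-out lower numbers stand for lower lipophilicity and higher numbers for higher lipophilicity), at 6.6. Compound 3 `O=C(C1CCN(c2ccccn2)CC1)N1N=CC[C@H]1c1ccccc1` comes nearest with 5.1, and compound 2 `CC(=O)N1CCC(C(=O)N2N=CC[C@H]2c2ccccc2)CC1` lies furthest away at 2.5. Among the compounds with values here, the one measured step, a number 2.60 log units higher from compound 2 to compound 3 (beyond the scatter), concerns a different part of the molecule and does not bear on the present change. Compound 4 `CC(C)(C)C(=O)N1N=CCC1c1cccc(F)c1` differs from compound 1 as follows: fluoro in place of chloro on an aromatic carbon. Within the data shown here, no measured pair covers fluoro in place of chloro on an aromatic carbon, so the expectation rests on the change itself: one halogen for another, with no change in donors, acceptors or charge. A small downward step, a number 0.60 log units lower from compound 1 to compound 4 (beyond the scatter), is expected. For compound 4 the estimate is 6, between 5.5 and 6.5.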

Compound 4, distribution coefficient: 5.9
The estimate for compound 4 lay 0.10 log units above the measured number; the range from low to high includes it.
By their numbers in this assay, from the lowest: compound 2; then compound 3; then compound 4; then compound 1.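

In this assay, fluoro in place of chloro on an aromatic carbon gives a number 0.70 log units lower from compound 1 to compound 4 (beyond the scatter) with no change in the counts of hydrogen-bond donors, acceptors or net charge. Within the data shown here, the earlier step concerned a different part of the molecule, so this is the first sign that the halogen at this place on the ring moves the number beyond the scatter. Nothing available explains the size of this step.

Still open, as far as these compounds go, is how a methoxy group, a nitrile or a plain hydrogen at this place would compare with chloro and fluoro. Also open, from the compounds shown here alone, is whether the same halogen exchange would give a similar step on another core.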